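A few compounds are considered here, and "the series" means these few. Any claim that something is new, unique, unknown or untested is made for them only; others in the source may bear on it.

The measured compounds:

compound 1: `N#C/C(=C\c1ccccc1OS(=O)(=O)c1ccc([N+](=O)[O-])cc1)C(=O)Nc1nnc(Cc2ccc(F)cc2)s1`, 8%
compound 2: `N#C/C(=C\c1ccccc1OS(=O)(=O)c1ccccc1[N+](=O)[O-])C(=O)Nc1nnc(Cc2ccc(F)cc2)s1`, 6%
compound 3: `Cc1ccc(Cc2nnc(NC(=O)/C(C#N)=C/c3ccccc3OS(=O)(=O)c3ccc([N+](=O)[O-])cc3)s2)cc1`, 9%

All three were tested in an ADME assay on HEK-293T cells (Homo sapiens) for inhibition, read by CCK-8 assay, with a stated time of 48 h, tested at 20 uM (on this read-out lower numbers stand for less inhibition of growth and higher numbers for more inhibition of growth at the one concentration tested), and all three sit close together on this read-out; none of the gaps between them goes beyond the usual scatter, so no ordering among them can be claimed.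

Compound 1 and compound 2 differ in one place only: 2-nitrophenyl in place of 4-nitrophenyl on a sulfonyl sulfur. That change made a small step, a number 2 percentage points lower from compound 1 to compound 2 (within the scatter). Compound 1 and compound 3 differ in their cores: methyl in place of fluoro on an aromatic carbon. That difference also made a small step, a number 1 percentage points higher from compound 1 to compound 3 (within the scatter).

Compound 4, `Cc1ccc(Cc2nnc(NC(=O)/C(C#N)=C/c3ccccc3OS(=O)(=O)c3ccccc3[N+](=O)[O-])s2)cc1`, has not yet been measured. It stands to compound 3 as compound 2 stands to compound 1: 2-nitrophenyl in place of 4-nitrophenyl on a sulfonyl sulfur. The place of the change is described in the same words for both pairs, a sulfonyl sulfur whose other neighbour is an oxygen on an aromatic ring, so this is the same change seen twice among these four compounds.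

For compound 4 a step of about the same small size is expected, a number 2 percentage points lower from compound 3 to compound 4 (within the scatter). That expectation rests on a number 2 percentage points lower from compound 1 to compound 2 (within the scatter), which is the only measurement of this change among these compounds, so a wide range is kept. Compound 4 is therefore expected to give 7% in this assay, with a likely range from 0% to 16%.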

Compound 4, percent growth inhibition at one concentration: 6%
Beside the measured number, compound 4's estimate is 1 percentage points above it; the measured number falls inside the stated range.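

Moving the nitro group, with 2-nitrophenyl in place of 4-nitrophenyl on the sulfonyl sulfur, gives in this assay a number 3 percentage points lower from compound 3 to compound 4 (within the scatter), and this step agrees with the one seen earlier on the other core: the same change on two cores in this assay, a number 2 percentage points lower (within the scatter) from compound 1 to compound 2 and a number 3 percentage points lower (within the scatter) from compound 3 to compound 4, 1 percentage points apart, within the scatter of two such steps. The other change, methyl in place of fluoro on an aromatic carbon, now read among the 2-nitrophenyl compounds, gives no change at the digits printed from compound 2 to compound 4 (within the scatter), and it agrees with its earlier reading in the same way: the same change on two cores in this assay, a number 1 percentage points higher (within the scatter) from compound 1 to compound 3 and no change at the digits printed (within the scatter) from compound 2 to compound 4, 1 percentage points apart, within the scatter of two such steps. Both changes therefore carry from one core to the other in this series, but only in a narrow sense: every step is too small to be told apart from repeat-to-repeat scatter, so this shows that neither change has a visible effect here, not that a real effect has been transferred, and it says nothing about whether a larger effect would carry over in the same way.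

The compounds shown leave open whether the growth of these cells would respond at all to a different group on the sulfonyl sulfur, such as a phenyl ring bearing an amine or a carboxylic acid in place of the nitro group. They also leave open what a longer chain would do in place of the methyl or fluoro on the aromatic carbon.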